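This account rests on a few compounds, and the source may have more. Where it says the series, first, only, none or still open, it means among the compounds named here.

Measured so far:
- compound 1, `CC(C)CN(Cc1ccccc1C(F)(F)F)S(=O)(=O)c1ccc2c(c1)C(=O)CC(C1CCOCC1)O2`: in a physicochemical assay for lipophilicity, at pH 7.4 (a lower number here means a more polar compound, a higher number a more lipophilic compound), compound 1 gives 4.32
- compound 2, `CCc1ccc(N(C2CCC2)S(=O)(=O)c2ccc3c(c2)C(=O)CC(C2CCOCC2)O3)cc1`: in this assay compound 2 gives 3.78

Of these two numbers, compound 1 holds the higher one, and the gap down to compound 2 lies beyond the scatter, so compound 1 is the more lipophilic of the pair. The two compounds differ in several places at once, so nothing can be said about which of those differences carries the gap.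

The next compound, compound 3, `CC(C)CN(c1ccccc1F)S(=O)(=O)c1ccc2c(c1)C(=O)CC(C1CCOCC1)O2`, keeps the shared core of compound 1 and alters only one group:

2-fluorophenyl in place of 2-(trifluoromethyl)benzyl on a sulfonamide nitrogen

The group that leaves is the larger of the two, and it carries a trifluoromethyl that the entering group does not; the counted difference shows the shrinkage. In this assay a change of this kind is expected to lower the number, and the step from compound 1 to compound 3 is estimated at a number 1.02 log units lower from compound 1 to compound 3 (beyond the scatter), well beyond the scatter. Compound 3 is therefore expected to come in at about 3.3, most likely between 2.8 and 3.8.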

Compound 3, distribution coefficient: 3.44
For compound 3 the middle estimate is 0.14 log units below the measured one; the range from low to high includes it.
By their numbers in this assay, from the lowest: compound 3; then compound 2; then compound 1.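

Within the data shown here, this is the first step that changes only one place, so a shift in this assay can now be tied to a single position: the group on a sulfonamide nitrogen. With the shared core and the other group on that nitrogen unchanged, 2-fluorophenyl in place of 2-(trifluoromethyl)benzyl gives a number 0.88 log units lower from compound 1 to compound 3 (beyond the scatter) and so shows that this position can move the number by more than the usual scatter. No measurement here explains the size of this step.

The exchange alters several things together, since the entering group has fewer heavy atoms, carries a single fluorine instead of a trifluoromethyl, and lacks the benzyl carbon, so the compounds shown do not divide the step among these differences. A 2-fluorobenzyl or an unsubstituted phenyl on the same nitrogen would help to separate them, while an amine or a carboxylic acid on that group would show how the number responds to a quite different kind of substituent.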